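A few compounds are considered here, and "the series" means these few. Any claim that something is new, unique, unknown or untested is made for them only; others in the source may bear on it.

Measured compounds:
- compound 1, `CC(C)c1ccccc1OS(=O)(=O)c1ccc(NC(=O)CCCl)cc1`, 16000 nM
- compound 2, `CCNC(=O)Nc1ccc(S(=O)(=O)Oc2ccccc2C(C)C)cc1`, 1100 nM

These two compounds share a core and differ only in the group attached to the carbonyl carbon. In a functional assay on HT-29 cells (Homo sapiens) for antiproliferative activity, read by sulforhodamine B assay, with a stated time of 48 h (on this read-out lower numbers stand for stronger inhibition and higher numbers for weaker inhibition), compound 2 gives 1100 nM, the lowest of the two numbers; compound 1 is the nearest, and the change between them is a 15-fold lower number from compound 1 to compound 2 (1.16 log units; beyond the scatter), a step well beyond the scatter.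

Compound 3, `CC(C)c1ccccc1OS(=O)(=O)c1ccc(NC(=O)NCCCCl)cc1`, has not yet been measured. It differs from compound 2 by chloromethyl in place of hydrogen on a saturated chain carbon, two bonds along the chain from an amide-type nitrogen, so the chain on the urea nitrogen grows from ethyl to 3-chloropropyl. For the measured compounds named here, the one measured step runs from compound 1 to compound 2 and swaps 2-chloroethyl on the carbonyl for ethylamino; it exchanges the whole group and says little about lengthening the chain of compound 2 and ending it in chlorine. Compound 1, which also carries a chlorine-terminated chain, is the weaker of the two. The change that separates compound 1 from compound 2 is not the change that separates compound 3 from compound 2. Going by the values given here, with no step that matches, the expectation is a number near that of compound 2, the step from compound 2 to compound 3 expected to be a 1.5-fold higher number from compound 2 to compound 3 (0.16 log units; within the scatter).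

For compound 3 the estimate in this assay is 1600 nM, within a range of 500 nM to 5000 nM.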

Compound 3, half-maximal inhibitory concentration: 6900 nM
Compound 3: middle estimate off by 4.3-fold (0.63 log units), on the low side, outside the stated range (above it).
By their numbers in this assay, from the lowest: compound 2; then compound 3; then compound 1.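

In this assay, chloromethyl in place of hydrogen on a saturated chain carbon, two bonds along the chain from an amide-type nitrogen, is not a silent change: the result is a 6.3-fold higher number from compound 2 to compound 3 (0.80 log units; beyond the scatter) and lies beyond the scatter. This is the first step shown that alters the chain alone, whereas the earlier step exchanged the whole group on the carbonyl carbon, and it shows that the number responds to a change at this chain carbon. Against the other compound with a chlorine-ended chain, the result is a 2.3-fold lower number from compound 1 to compound 3 (0.37 log units; beyond the scatter) and so (3-chloropropyl)amino on the carbonyl carbon gives a lower number than 2-chloroethyl, though not as low as ethylamino.

The compounds shown cannot separate the effect of the longer chain from that of the chlorine, and a plain propyl chain at the same place would be needed to pull these apart. On these data alone, it also remains open how a 3-hydroxypropyl chain, a 3-aminopropyl chain or the shorter (2-chloroethyl)amino group would read here.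

No measurement offered here explains the size or direction of these steps.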